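A few compounds are considered here, and "the series" means these few. Any claim that something is new, unique, unknown or untested is made for them only; others in the source may bear on it.

Of the compounds shown here, two have been tested so far in a functional assay on HL-60 cells (Homo sapiens); a higher number here means that more compound is needed for the effect, a lower number that less compound is needed. Compound 1 `CC1(C)CCC(C)(C)c2cc(-c3cc(-c4ccc(C(=O)O)cc4)no3)ccc21` gives 5000 nM in this assay. Compound 2 `CC1(C)CCC(C)(C)c2cc(CNc3ccc(C(=O)O)cc3)ccc21` gives 70000 nM in this assay, which is the higher of the two numbers; compound 1 sits at a lower number, and that gap lies beyond the usual scatter of repeated measurements. For the measured compounds named here, no single-change step between measured compounds is available, so nothing is known yet about how small changes at the linker shift the number in this assay.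

Compound 3 `CN(Cc1ccc2c(c1)C(C)(C)CCC2(C)C)c1ccc(C(=O)O)cc1` is the next compound to be measured. It differs from compound 2 by methyl in place of hydrogen on a nitrogen on an aromatic ring. Going by the values given here, because no step between measured compounds is known, the expectation for this change rests on nothing more than the shared core and the small size of the change. The step from compound 2 to compound 3 in this assay is therefore expected to be small, roughly a 1.4-fold lower number from compound 2 to compound 3 (0.15 log units; within the scatter), and may well fall within the scatter. For compound 3 the estimate in this assay is 50000 nM, with a range from 10000 nM to 200000 nM.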

Compound 3, concentration for half-maximal activity: 95000 nM
For compound 3 the middle estimate is 1.9-fold (0.28 log units) below the measured one, within the range that was stated.
By their numbers in this assay, from the lowest: compound 1; then compounds 2 and 3 (each within the scatter of the next).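

For the compounds shown here, the swap of methyl in place of hydrogen on a nitrogen on an aromatic ring gives the first single-change step at the linker in this assay, and it reads a 1.4-fold higher number from compound 2 to compound 3 (0.13 log units; within the scatter). Compounds 2 and 3 therefore cannot be told apart in this assay, so at this one position the hydrogen on the nitrogen and a methyl group give numbers that repeated measurements could not separate, which the earlier pair of compounds, differing in more than one place, could not show. No independent measurement bears on this result, so it stands as an observation without an explanation.

What the compounds shown leave open is whether this tolerance holds only for methyl or also for a larger group on the same nitrogen, such as an ethyl group, a longer chain or an acetyl group. Also open, as far as these compounds go, is what would happen if that nitrogen gave way to an oxygen atom or an amide, since a single step at one position says nothing about other groups there.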